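The source may report more compounds than this note shows. Statements on the series, on what has been measured and on what is new or still open speak of the compounds shown alone.

Working notes on the series, following the substituent on the aromatic nitrogen. In a functional assay on FaDu cells (Homo sapiens) for cytotoxicity, read by MTT assay, with a stated time of 72 h (on this read-out higher numbers stand for lower toxicity in this test and lower numbers for higher toxicity in this test), compound 1 (`COc1ccc(NC(=O)C(=O)c2cn(C(C)(C)COCC(=O)O)c3ccccc23)cn1`) gives > 10000 nM, which is a limit of the assay and not a number. Compound 2 (`CCn1cc(C(=O)C(=O)Nc2ccc(OC)nc2)c2ccccc21`) gives 219 nM and compound 3 (`COc1ccc(NC(=O)C(=O)c2cn(C(C)C)c3ccccc23)cn1`) gives 85 nM, the lower of the two actual numbers in the series.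

The next change leads to compound 4 (`COC(=O)CCn1cc(C(=O)C(=O)Nc2ccc(OC)nc2)c2ccccc21`), with 2-(methoxycarbonyl)ethyl in place of isopropyl on an aromatic nitrogen.

Two kinds of measured step bear on this. Between the two small groups the shift is modest, with a 2.6-fold lower number from compound 2 to compound 3 (0.41 log units; beyond the scatter). The long chain of compound 1 stands against both small groups, with large steps: an at least 45-fold lower number from compound 1 to compound 2 (1.65 log units; beyond the scatter) and an at least 110-fold lower number from compound 1 to compound 3 (2.07 log units; beyond the scatter). The entering chain is also longer than isopropyl, but it ends in methoxycarbonyl and has no net charge, and it lacks the carboxymethoxy part of compound 1. Only a small part of the large step in an at least 110-fold lower number from compound 1 to compound 3 (2.07 log units; beyond the scatter) is therefore expected to carry over, and a modest to moderate move towards a higher number in this assay is expected. The expected size is a 4.7-fold higher number from compound 3 to compound 4 (0.67 log units; beyond the scatter). For compound 4 the estimated value is 400 nM, with an expected range of 100 nM to 2500 nM.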

Compound 4, concentration lethal to 50% of the cells: 168 nM
Compound 4: middle estimate off by 2.4-fold (0.38 log units), on the high side, within the range that was stated.
By their numbers in this assay, from the lowest: compounds 3, 4 and 2 (each within the scatter of the next, the first and the last beyond it). At a limit, above all of these: compound 1.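

In this assay, the 2-(methoxycarbonyl)ethyl chain on the aromatic nitrogen cannot be told apart from either small group: a 2.0-fold higher number from compound 3 to compound 4 (0.30 log units; within the scatter), and a 1.3-fold lower number from compound 2 to compound 4 (0.12 log units; within the scatter). A longer group at this position, with 2 hydrogen-bond acceptors and no net charge, is therefore tolerated here, and a greater number of heavy atoms on the aromatic nitrogen does not by itself go with a large move towards a higher number, while the large gap to the chain of compound 1 remains: an at least 59-fold lower number from compound 1 to compound 4 (1.77 log units; beyond the scatter). Compound 1 gives > 10000 nM, which is a limit of the assay and not a number.

Still open, going by these compounds, is whether that large step goes with the carboxylic acid at the end of the chain in compound 1 or with the rest of that chain, as the groups of compound 1 and compound 4 differ in more than their ends. Also open, on these data alone, is how a carboxylic acid on the plain ethyl chain, an amine at the chain end or a longer chain ending in methoxycarbonyl would read in this assay.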